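Amide side chain: ester to amine swap, second core

The compounds below may be only part of what the source reports. "The series", "measured", "known", "first", "only" and "open" are said of these compounds alone.

Measured so far in a functional assay on PC-3 cells (Homo sapiens) for antiproliferative activity, read by MTT assay, with a stated time of 72 h; a lower number here means a stronger inhibitor, a higher number a weaker inhibitor:
compound 1 `CCn1c(C(=O)NCCC(=O)OC)ccc1C(CC)(CC)c1ccc(C#CC(O)(CC)CC)c(C)c1`: 36300 nM
compound 2 `CCN(CC)CCCNC(=O)c1ccc(C(CC)(CC)c2ccc(C#CC(O)(CC)CC)c(C)c2)n1CC`: 8500 nM
compound 3 `CCn1cc(C(CC)(CC)c2ccc(C#CC(O)(CC)CC)c(C)c2)cc1C(=O)NCC(=O)OC`: 17500 nM

Compound 1 and compound 2 share one core and differ in the amide side chain: (diethylamino)methyl in place of methoxycarbonyl on a saturated chain carbon, two bonds along the chain from an amide-type nitrogen. On that change the read-out moved by a 4.3-fold lower number from compound 1 to compound 2 (0.63 log units; beyond the scatter), which is beyond the scatter of repeated runs, though the absolute numbers remain in the weak range.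

Compound 3 sits on a second core; the difference between the two cores is not broken down here. Compound 3 lies between compound 1 and compound 2, its gap to each of them beyond the scatter, so on the ester-bearing side chain the second core reads lower than the first.

Compound 4 `CCN(CC)CCNC(=O)c1cc(C(CC)(CC)c2ccc(C#CC(O)(CC)CC)c(C)c2)cn1CC` has not yet been measured. It differs from compound 3 by (diethylamino)methyl in place of methoxycarbonyl on a saturated chain carbon bound to an amide-type nitrogen. This is the same kind of change as that from compound 1 to compound 2, but not the same: there the carbon carrying the group was two bonds along the chain from the amide-type nitrogen, here it is bound to the amide-type nitrogen. For the measured compounds named here, with only one earlier example, the expectation rests on that single step, a 4.3-fold lower number from compound 1 to compound 2 (0.63 log units; beyond the scatter), and a step of about a 3.9-fold lower number from compound 3 to compound 4 (0.59 log units; beyond the scatter) is expected here, with wide room either way as the place of the change is not the same. Compound 4 is therefore estimated at 4500 nM, between 1500 nM and 13000 nM.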

Compound 4, half-maximal inhibitory concentration: 5350 nM
Estimate against measurement, compound 4: 1.2-fold (0.08 log units) below, within the range that was stated.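

In this assay, (diethylamino)methyl in place of methoxycarbonyl on a saturated chain carbon bound to an amide-type nitrogen gives a 3.3-fold lower number from compound 3 to compound 4 (0.51 log units; beyond the scatter), so the lower number seen on the core of compound 1 also appears on the core of compound 3. Set beside the earlier step, the change carries from one core to the other with no size difference that can be told apart: the same change on two cores in this assay, a 4.3-fold lower number (0.63 log units; beyond the scatter) from compound 1 to compound 2 and a 3.3-fold lower number (0.51 log units; beyond the scatter) from compound 3 to compound 4, 1.3-fold (0.12 log units) apart, within the scatter of two such steps This rests on only two pairs, and the place of the change is not the same in them, so the result shows a similar step for this ester-to-amine swap but does not separate the effect of the core from that of the chain, nor does it establish a rule for other cores.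

On these data alone, it remains open whether chain length alters the step on a single core, as the 2-(diethylamino)ethyl chain appears here only on the core of compound 3 and the longer amine chain of compound 2 only on the other core. Also open, as far as these compounds go, is whether the step holds for other side-chain ends, such as a carboxylic acid in place of the ester or a primary amine or dimethylamino group in place of the diethylamino group.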